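Adding a Hydroxy Group to Compound 1

The compounds below may be only part of what the source reports. "The series", "measured", "known", "first", "only" and "open" are said of these compounds alone.

Compound 1 `COc1ccc(Cc2ccc3ccccc3c2)c(OC)c1OC`: > 10000 nM
Compound 2 `CCn1ccc2cc(Cc3ccc(OC)c(OC)c3OC)ccc21`: > 1000 nM

Both compounds were tested in a functional assay on HT-29 cells (Homo sapiens) for cytotoxicity, read by XTT assay, with a stated time of 72 h (a lower number here means a stronger inhibitor, a higher number a weaker inhibitor), and neither yielded a number. For compound 1, the result is a limit, > 10000 nM. For compound 2, the result is also a limit, > 1000 nM. Compound 1 therefore has no measured potency in this assay, and the two limits cannot be used to rank the compounds. For the measured compounds named here, no measured step between closely related compounds is available as a guide.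

Compound 3 `COc1ccc(C(O)c2ccc3ccccc3c2)c(OC)c1OC` keeps the core of compound 1 and differs by hydroxy in place of hydrogen on a saturated chain carbon bound to two aromatic carbons. Going by the values given here, with no measured step to scale from, the expectation rests on this single change and is deliberately cautious. A modest move toward a lower number in this assay is expected, though a result that is again only a limit remains quite possible. The expected change is an at least 1.2-fold lower number from compound 1 to compound 3 (0.09 log units; that floor lies within the scatter). For compound 3, the estimated value is 8000 nM, with an expected range of 1000 nM to 30000 nM.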

Compound 3, half-maximal inhibitory concentration: > 10000 nM
Compound 3: only a limit was reported; the forecaster's own chance of this, stated with the estimate: 55%; at least 1.2-fold (0.09 log units) between middle value and limit.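

In this assay compound 3 gives > 10000 nM and this is a limit. No step can be read from compound 1 to compound 3 because both carry the same limit: the limit of > 10000 nM in this assay, at which 2 of the 3 values shown sit.

The compounds shown leave open whether hydroxy in place of hydrogen on a saturated chain carbon bound to two aromatic carbons changes potency in this assay at all.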